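This account rests on a few compounds, and the source may have more. Where it says the series, first, only, none or still open, it means among the compounds named here.

The compounds measured so far in a functional assay on L1210 cells (Mus musculus) for antiproliferative activity, with a stated time of 48 h (a higher number here means a weaker inhibitor, a lower number a stronger inhibitor), are:

Compound 1 `C=C(Br)C(=O)Nc1ccc(C(=O)/C=C/c2ccccc2)cc1`: 880 nM
Compound 2 `C=C(Br)C(=O)Nc1ccc(C(=O)/C=C/c2ccccc2OC)cc1`: 1700 nM
Compound 3 `C=C(Br)C(=O)Nc1ccc(C(=O)/C=C/c2ccc(OC)c(OC)c2)cc1`: 1300 nM

Compound 1 has the lowest number of the three, but its nearest neighbour, compound 3, lies within the scatter of it, and so does compound 2. Going by the values given here, the one step measured between compounds differing in a single place, a 1.9-fold higher number from compound 1 to compound 2 (0.29 log units; within the scatter), is itself within the scatter, and the two values of compound 1 and compound 3 show no separation either.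

Compound 4 `C=C(Br)C(=O)Nc1ccc(C(=O)/C=C/c2ccc(N(C)C)cc2)cc1` has not yet been measured in this assay. It differs from compound 1 by dimethylamino in place of hydrogen on an aromatic carbon. Among the compounds with values here, no measured step puts a dimethylamino group anywhere on this core, so the only guide is that substitution on that ring, in compound 2 and compound 3, has so far left the numbers within the scatter of compound 1. Compound 4 is therefore expected to show a step of about a 1.4-fold higher number from compound 1 to compound 4 (0.13 log units; within the scatter), not clearly beyond the scatter. The estimate for compound 4 is 1200 nM, with a range from 400 nM to 3600 nM.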

Compound 4, half-maximal inhibitory concentration: 1900 nM
Compound 4: middle estimate off by 1.6-fold (0.20 log units), on the low side; measured number inside the range.
By their numbers in this assay, from the lowest: compounds 1, 3, 2 and 4 (each within the scatter of the next, the first and the last beyond it).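

In this assay, going by these compounds alone, dimethylamino in place of hydrogen on an aromatic carbon, para to a large group, brings a 2.2-fold higher number from compound 1 to compound 4 (0.33 log units; beyond the scatter) and so gives the first single-place change on the core of compound 1 to lie beyond the scatter. Within the data shown here, the earlier methoxy change, with a 1.9-fold higher number from compound 1 to compound 2 (0.29 log units; within the scatter), stayed within it, so this result is the first sign that substitution on this ring can shift the number at all, although the shift is modest and compound 4 remains measurable in the same range of concentrations. Nothing available here accounts for the step.

Still open, as far as these compounds go, is whether a plain amino group, a carboxylic acid or a fluorine atom at this same place would give a step of similar size. The compounds shown also leave open whether a longer chain on the nitrogen would move the number further than dimethylamino does.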